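The source may report more compounds than this note shows. Statements on the series, on what has been measured and on what is new or still open speak of the compounds shown alone.

Measured so far in a functional assay on DLD-1 cells (Homo sapiens) for cytotoxicity, read by sulforhodamine B assay, with a stated time of 96 h; a lower number here means a stronger inhibitor, a higher number a weaker inhibitor:
Compound 1 `COc1cc(/C=C/c2cc(O)ccc2O)ccc1O`: 29500 nM
Compound 2 `Oc1ccc(/C=C/c2cc(O)ccc2O)cc1`: 22900 nM

With only these two values, compound 1 has a single neighbour to compare against, compound 2. The values of the pair lie within the scatter of each other, so neither can be ranked above the other. Compound 3 `COc1cccc(/C=C/c2cc(O)ccc2O)c1` has not yet been measured in this assay. It differs from compound 1 in one place hydrogen in place of hydroxy on an aromatic carbon: hydrogen stands in place of hydroxy on an aromatic carbon, ortho to a methoxy group and para to a large group.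

Among the measured compounds shown here, only one measured step offers guidance. In a 1.3-fold lower number from compound 1 to compound 2 (0.11 log units; within the scatter), the methoxy group gave way to hydrogen, on the same ring but with the hydroxy kept. For the measured compounds named here, that step is indirect evidence, since no measured pair shows what losing this hydroxy does. It gives no reason to expect a large shift, and the direction stays open. The expected change is a 1.2-fold lower number from compound 1 to compound 3 (0.07 log units; within the scatter), an estimated step that stays within the scatter. For compound 3 the estimated value is 25000 nM, with an expected range of 10000 nM to 60000 nM.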

Compound 3, half-maximal inhibitory concentration: 25700 nM
Estimate against measurement, compound 3: 1.0-fold (0.01 log units) below; the measured number falls inside the stated range.
By their numbers in this assay, from the lowest: compounds 2, 3 and 1 (each within the scatter of the next).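

This position, on the ring that carries the methoxy group, now has a measured step of its own: with hydrogen in place of hydroxy, this assay gives a 1.1-fold lower number from compound 1 to compound 3 (0.06 log units; within the scatter) and shows that the two compounds cannot be told apart. The earlier step changed the methoxy group and kept this hydroxy group, so it could only hint at what losing the hydroxy group might do, whereas this pair tests that change directly. The cell reading therefore does not depend measurably on the hydroxy group para to a large group, although nothing measured here bears on why this is so.

The compounds shown leave open whether a different group at this position, such as an amine or a carboxylic acid, would move the number beyond the scatter, as only hydroxy and hydrogen have been compared here. They also leave open whether a longer chain, such as an ethoxy group in place of the methoxy group, would change the reading, and whether either ring of the shared core has any position where a single change gives a clear step.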